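The compounds below may be only part of what the source reports. "The series", "measured", "known", "first", "only" and "open" are said of these compounds alone.

Working notes on an ADME assay on MT4 cells (Homo sapiens) for cytotoxicity, read by MTT assay, with a stated time of 5 days; on this read-out higher numbers stand for lower toxicity in this test and lower numbers for higher toxicity in this test. Among the measured compounds shown here, compound 1 (`COc1cc2nc(Nc3ccc(C#N)cc3)nc(Nc3c(C)cc(/C=C/C#N)cc3C)c2cc1OC`) gives 10200 nM, the only true number so far. Compound 2 (`COc1cc2nc(SCC(=O)Nc3cccc(S(N)(=O)=O)c3)nc(Nc3c(Cl)cc(/C=C/C#N)cc3Cl)c2cc1OC`) is reported as a limit, > 194000 nM, and not as a number. The two values show compound 2 on the higher-number side of compound 1, but the open end leaves the size of that gap unknown.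

Compound 3 (`COc1cc2nc(SCC(=O)Nc3cccc(Cl)c3)nc(Nc3c(Cl)cc(/C=C/C#N)cc3Cl)c2cc1OC`) keeps the rest of compound 2 and carries chloro in place of sulfamoyl on an aromatic carbon, meta to a large group: chloro in place of sulfamoyl on an aromatic carbon. In the same terms, this is 3-sulfamoylphenyl to 3-chlorophenyl. For the measured compounds named here, no measured pair covers this change, so any forecast is loose.

The expected change is an at least 3.8-fold lower number from compound 2 to compound 3 (0.58 log units; beyond the scatter), a move towards lower numbers and so higher toxicity, and it is expected to exceed the usual scatter. Going by the values given here, the one numeric anchor is compound 1 at 10200 nM, which sets the lower side of the expectation. For compound 3 the estimated half-maximal cytotoxic concentration in this assay is 50000 nM, with an expected range of 10000 nM to 200000 nM.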

Compound 3, half-maximal cytotoxic concentration: > 208000 nM
Compound 3: no number, only a limit; the forecaster's own chance of this, stated with the estimate: 35%; at least 4.1-fold (0.61 log units) between middle value and limit.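

Among the compounds shown here, compound 2 and compound 3 are both reported only as limits in this assay, and no step for chloro in place of sulfamoyl can be read between them. The compounds shown leave open how far either true value lies past its limit, and whether 3-sulfamoylphenyl to 3-chlorophenyl changes this read-out at all.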